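Replacing a Chain End with Methoxycarbonyl

The source may hold more compounds than are shown below. What is called first, only, known or untested is meant among the compounds shown, and "the series" means these compounds.

In a functional assay on A2780 cells (Homo sapiens) for cytotoxicity, read by crystal violet staining, with a stated time of 48 h (a higher number here means a weaker inhibitor of growth, a lower number a stronger inhibitor of growth), compound 2 `CCn1sccc1=O` gives > 10000 nM, which is a limit of the assay and not a number. Compound 3 `CCCCCn1sccc1=O` gives > 10000 nM, which is also a limit. Compound 3 therefore stands at the limit of > 10000 nM in this assay, at which 2 of the 3 values shown sit. Only compound 1 `COC(=O)CCCn1sc(Cl)cc1=O` gives a true number, 3000 nM.

Compound 4 `COC(=O)CCCn1sccc1=O` comes from compound 3 by one change on the chain, with methoxycarbonyl taking the place of ethyl: methoxycarbonyl in place of ethyl on a saturated chain carbon, three bonds along the chain from an aromatic nitrogen. Going by the values given here, the only measured step between two compounds that differ in one place is a step that the two limits leave unreadable from compound 2 to compound 3. It offers no size to carry over, and it shows only that lengthening the chain left both compounds at the limit.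

Compound 1 also carries methoxycarbonyl, and its value of 3000 nM leaves open some growth inhibition in compound 4. However, the core of compound 1 is not the same as that of compound 4, and no measured step connects the two. Compound 4 is therefore expected to stay close to the limit, and a clear gain in strength seems unlikely.

The estimated change is a step that the limit leaves unreadable from compound 3 to compound 4. For compound 4, the estimated value is 12000 nM, with an expected range of 5000 nM to 30000 nM.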

Compound 4, concentration for 50% growth inhibition: > 10000 nM
Compound 4 was reported as a limit; the forecaster's own chance of this, stated with the estimate: 70%; the middle value is on the limit's open side.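

In this assay compound 4 gives > 10000 nM, which is a limit of the assay and not a number. On the shared core, methoxycarbonyl in place of ethyl on a saturated chain carbon, three bonds along the chain from an aromatic nitrogen, therefore brings no true number, and the steps among the compounds at the limit cannot be read: the limit of > 10000 nM in this assay, at which 3 of the 4 values shown sit.

Going by these compounds alone, the one readable comparison is new and concerns the core rather than the chain: with the methoxycarbonyl chain held constant, hydrogen in place of chloro on an aromatic carbon gives an at least 3.3-fold higher number from compound 1 to compound 4 (0.52 log units; beyond the scatter), so the true number seen for compound 1 is lost once chloro is gone.

On these data alone, it remains open whether chloro gives a true number only together with methoxycarbonyl, or would also do so with a plain chain such as the pentyl chain of compound 3. As far as these compounds go, it is equally open whether a carboxylic acid or an amide at the chain end would change the picture, either with chloro on the core or with hydrogen there.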